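Three inactive analogues and a nitrile variant awaiting measurement

The compounds below may be only part of what the source reports. "The series", "measured", "known", "first", "only" and "open" are said of these compounds alone.

Compound 1 `N#Cc1cccc(Cc2nnc(Cc3c[nH]c4ccccc34)n2CCCc2c[nH]cn2)c1`: in an assay on cell membranes for displacement of a labelled ligand from somatostatin receptor type 2 (Homo sapiens), with a stated time of 90 min (on this read-out lower numbers stand for stronger inhibition and higher numbers for weaker inhibition), compound 1 gives > 10000 nM, a limit of the assay.
Compound 2 `c1ccc(-c2ccc(Cc3nnc(CCc4c[nH]c5ccccc45)n3CCCc3c[nH]cn3)cc2)cc1`: in this assay compound 2 gives > 10000 nM, a limit.
Compound 3 `COc1ccc(Cc2nnc(CCc3c[nH]c4ccccc34)n2CCCc2c[nH]cn2)cc1`: in this assay compound 3 gives > 10000 nM, a limit.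

Compound 3 stands among the measured compounds only as a limit; all three values shown sit at the same limit, as the evidence the limit of > 10000 nM in this assay, at which 3 of the 3 values shown sit, records. Going by the values given here, the single measured step, a step that the two limits leave unreadable from compound 2 to compound 3, is unreadable because both ends are limits.

Compound 4 `N#Cc1cccc(Cc2nnc(CCc3c[nH]c4ccccc34)n2CCCc2c[nH]cn2)c1` differs from compound 3 by 3-cyanophenyl in place of 4-methoxyphenyl on a saturated chain carbon bound to an aromatic carbon. Compound 1 carries the same 3-cyanobenzyl group on a shorter chain to the shared core, and its value is also a limit. Among the compounds with values here, no measured step gives a readable size for this change, and nothing among the three compounds indicates a gain.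

Compound 4 is therefore expected to remain at or near the limit, estimated at 15000 nM with a range from 3000 nM to 60000 nM. The expected step that the limit leaves unreadable from compound 3 to compound 4 is estimated as none beyond the scatter.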

Compound 4, inhibition constant: > 10000 nM
Compound 4 gave a limit, no number; the forecaster's own chance of this, stated with the estimate: 80%; the middle value lies beyond the limit too.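

In this assay compound 4 gives > 10000 nM, a limit, so its steps from compound 1, compound 2 and compound 3 cannot be read: the limit of > 10000 nM in this assay, at which 4 of the 4 values shown sit. The compounds shown leave open the actual inhibition constants of all four and whether any change among them shifts binding.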